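Fluorophenyl for phenethyl at the chain end of compound 3

The source may report more compounds than this note shows. Statements on the series, on what has been measured and on what is new or still open speak of the compounds shown alone.

Measured compounds:
compound 1 `O=C(NCCCCc1cccs1)n1c(=O)oc2ccccc21`: 37 nM
compound 2 `O=C(NCCCCc1ccc([N+](=O)[O-])cc1)n1c(=O)oc2ccccc21`: 312 nM
compound 3 `O=C(NCCCCCCc1ccccc1)n1c(=O)oc2ccccc21`: 51 nM

In an assay on HEK293 cells for inhibition of acid ceramidase (Homo sapiens), with a stated time of 10 min (on this read-out higher numbers stand for weaker inhibition and lower numbers for stronger inhibition), compound 3 gives 51 nM, the second highest of the three numbers. Its nearest neighbour is compound 1, whose value of 37 nM lies within the scatter of it; the furthest is compound 2 with 312 nM, a gap that lies beyond the scatter. Compound 4 `O=C(NCCCCc1ccc(F)cc1)n1c(=O)oc2ccccc21` has not yet been measured. It differs from compound 3 in one place: 4-fluorophenyl in place of phenethyl on a saturated chain carbon, four bonds along the chain from an amide-type nitrogen.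

For the measured compounds named here, only one measured step touches this position on the chain, a 1.4-fold higher number from compound 1 to compound 3 (0.14 log units; within the scatter), and it stays within the scatter, so exchanging one small aromatic group for another at this carbon has so far left the number almost unchanged. Going by the values given here, compound 2 shows that a differently substituted aromatic ring at the same carbon can raise the number well beyond the scatter, but no single-change step connects it to compound 3. For compound 4 the step of a 1.2-fold higher number from compound 3 to compound 4 (0.07 log units; within the scatter) is therefore expected to stay within the scatter in this assay. Compound 4 is estimated at 60 nM, in the range 25 nM to 150 nM.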

Compound 4, half-maximal inhibitory concentration: 75 nM
For compound 4 the middle estimate is 1.3-fold (0.10 log units) below the measured one; measured number inside the range.
By their numbers in this assay, from the lowest: compounds 1, 3 and 4 (each within the scatter of the next, the first and the last beyond it); then compound 2.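

In this assay the exchange of phenethyl for 4-fluorophenyl on the saturated chain carbon stays within the scatter (a 1.5-fold higher number from compound 3 to compound 4 (0.17 log units; within the scatter)), so at this place the two groups cannot be told apart. The same place now also gives its first step beyond the scatter, though only a modest one, when 4-fluorophenyl stands in place of thiophen-2-yl (a 2.0-fold higher number from compound 1 to compound 4 (0.31 log units; beyond the scatter)), which separates these two groups even though compound 3 lies within the scatter of both compound 1 and compound 4. For the compounds shown here, the new compound also gives the first direct reading of the substituent on the aromatic carbon, where fluoro in place of nitro brings a larger step, also beyond the scatter (a 4.2-fold lower number from compound 2 to compound 4 (0.62 log units; beyond the scatter)), showing that with the chain unchanged this substituent alone moves the number.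

As far as these compounds go, it remains open whether a plain phenyl, or a chloro, methoxy or amino group on that aromatic carbon, would fall nearer to the fluoro or to the nitro compound, and how a longer chain carrying 4-fluorophenyl would read. Nothing among the available measurements accounts for any of these differences.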